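This account rests on a few compounds, and the source may have more. Where it says the series, first, only, none or still open, it means among the compounds named here.

Three compounds built on one shared core differ only in the group attached to the double-bonded chain carbon. Compound 1 `O=C1/C(=C\c2ccc(F)cc2)c2ccccc2N1c1c(Cl)cccc1Cl` carries a fluorophenyl there, and in a functional assay on KB cells (Homo sapiens) for cytotoxicity, read by MTT assay, with a stated time of 72 h (on this read-out lower numbers stand for an effect already at smaller amounts and higher numbers for an effect only at larger amounts of compound), compound 1 gives 5 ug/mL. Compound 2 `COc1ccc(/C=C2\C(=O)N(c3c(Cl)cccc3Cl)c3ccccc32)cc1` carries a 4-methoxyphenyl instead. In this assay compound 2 reaches only > 100 ug/mL, which is a limit of the measurement and not a number. Compound 3 `COc1ccc(/C=C2\C(=O)N(c3c(Cl)cccc3Cl)c3ccccc32)cc1OC` adds a second methoxy, and in this assay compound 3 gives 10 ug/mL. The first step, an at least 20-fold higher number from compound 1 to compound 2 (1.30 log units; beyond the scatter), made the compound far weaker, and the second, an at least 10-fold lower number from compound 2 to compound 3 (1.00 log units; beyond the scatter), brought the effect back. Compound 2 therefore stands at the weak end of the three, known only through (the limit of > 100 ug/mL in this assay, at which 1 of the 3 values shown sits).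

Compound 4 `O=C1/C(=C\c2ccccc2[N+](=O)[O-])c2ccccc2N1c1c(Cl)cccc1Cl` alters the same position once more: 2-nitrophenyl in place of 4-methoxyphenyl on a double-bonded chain carbon bound to a double-bonded ring carbon. Neither measured step exchanges the whole ring, so they bear on this change only loosely, yet both show that a single alteration here can move the result by a large margin in either direction. Since compound 2 sits at the limit, any measurable number for compound 4 would be a lower one. A downward step of about the size seen in an at least 10-fold lower number from compound 2 to compound 3 (1.00 log units; beyond the scatter) is expected, so the expected change is an at least 5.0-fold lower number from compound 2 to compound 4 (0.69 log units; beyond the scatter). Compound 4 is thus estimated to give about 20 ug/mL, within a range from 5 ug/mL to 100 ug/mL.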

Compound 4, concentration for half-maximal effect: 1 ug/mL
Estimate against measurement, compound 4: 20-fold (1.30 log units) above; measured number outside the range, below it.
By their numbers in this assay, from the lowest: compound 4; then compounds 1 and 3 (each within the scatter of the next). At a limit, above all of these: compound 2.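

Exchanging the whole ring on the double-bonded chain carbon, and not just one group on it, gives an at least 100-fold lower number from compound 2 to compound 4 (2.00 log units; beyond the scatter) in this assay, so this position accepts 2-nitrophenyl and a much larger swing in the result than the methoxy steps had revealed. The gain does not depend on starting from a poor compound, since the change still counts against the 4-fluorophenyl compound, with a 5.0-fold lower number from compound 1 to compound 4 (0.70 log units; beyond the scatter), a modest step but one that lies beyond the usual scatter. The size of the first step is only a lower bound, as compound 2 has a limit and not a number: the limit of > 100 ug/mL in this assay, at which 1 of the 4 values shown sits.

Moving from 4-fluorophenyl or 4-methoxyphenyl to 2-nitrophenyl alters both the group and where it sits on the ring, so the compounds shown cannot tell these two changes apart, and a 4-nitrophenyl or a 2-methoxyphenyl would separate them. From the compounds shown here alone, it also remains open how this position would respond to a ring carrying an amine or a carboxylic acid, and the numbers here give no reason for any of these steps.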